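Sulfonyl aryl variation: carboxyphenyl replaces trifluoromethylphenyl

The compounds below may be only part of what the source reports. "The series", "measured", "known", "first", "only" and "open" are said of these compounds alone.

Going by the values given here, compound 3 `COc1cc2nc(N3CCN(S(=O)(=O)c4ccc(C(F)(F)F)cc4)CC3)nc(N)c2cc1OC` gives 27000 nM in a functional assay on PC-3 cells (Homo sapiens) for inhibition (on this read-out lower numbers stand for stronger inhibition and higher numbers for weaker inhibition), the highest of the three numbers so far, though every step to it stays within the scatter: a 1.2-fold higher number from compound 1 to compound 3 (0.07 log units; within the scatter) and a 1.4-fold higher number from compound 2 to compound 3 (0.13 log units; within the scatter), with compound 1 `COc1cc2nc(N3CCN(S(=O)(=O)c4ccc(Cl)cc4)CC3)nc(N)c2cc1OC` at 23000 nM and compound 2 `COc1cc2nc(N3CCN(S(=O)(=O)c4ccc(Br)cc4)CC3)nc(N)c2cc1OC` at 20000 nM. Compound 4 `COc1cc2nc(N3CCN(S(=O)(=O)c4cccc(C(=O)O)c4)CC3)nc(N)c2cc1OC` brings (3-carboxyphenyl in place of 4-(trifluoromethyl)phenyl on a sulfonyl sulfur). Among the compounds with values here, no measured step bears on this change; the three steps compare only chloro, bromo and trifluoromethyl, and all, including a 1.2-fold lower number from compound 1 to compound 2 (0.06 log units; within the scatter), lie within the scatter. The measured compounds give no footing for a carboxyl group, so no shift beyond the scatter is expected in this assay, but with wide uncertainty. Compound 4 is estimated at 25000 nM in this assay, within 8000 nM to 80000 nM. This estimate corresponds to an expected step of a 1.1-fold lower number from compound 3 to compound 4 (0.03 log units; within the scatter).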

Compound 4, half-maximal inhibitory concentration: 53000 nM
For compound 4 the middle estimate is 2.1-fold (0.33 log units) below the measured one, and the stated range covers the measured number.
By their numbers in this assay, from the lowest: compounds 2, 1, 3 and 4 (each within the scatter of the next, the first and the last beyond it).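

In this assay, going by these compounds alone, the 3-carboxyphenyl group on the sulfonyl sulfur gives the first steps beyond the scatter at this position, a 2.7-fold higher number from compound 2 to compound 4 (0.42 log units; beyond the scatter) and a 2.3-fold higher number from compound 1 to compound 4 (0.36 log units; beyond the scatter) while a 2.0-fold higher number from compound 3 to compound 4 (0.29 log units; within the scatter) stays within it. The aryl group here therefore has some modest influence on the read-out, which the halogen and trifluoromethyl compounds did not show. No evidence at hand accounts for this shift.

The change alters both the group and its ring position, and these remain unseparated. On these data alone, whether a 4-carboxyphenyl group, a methyl ester or an amine would behave alike remains open.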